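A few compounds are considered here, and "the series" means these few. Any claim that something is new, unique, unknown or untested is made for them only; others in the source may bear on it.

Series notes. Compound 1 `CSCc1ccc(Nc2ncc(Cc3c(F)cccc3F)o2)cc1` is recorded at > 100000 nM in an ADME assay on MT2 cells (Homo sapiens) for cytotoxicity, read by MTT assay; on this read-out lower numbers stand for higher toxicity in this test and higher numbers for lower toxicity in this test; this is a limit of the assay and not a number (the limit of > 100000 nM in this assay, at which 1 of the 3 values shown sits). Compound 2 `Fc1cccc(F)c1Cc1cnc(Nc2ccc(Oc3cccnc3)c(Cl)c2)o1` gives 16000 nM in this assay. Compound 3 `Clc1cccc(Cl)c1Cc1nnc(Nc2ccc(COCc3ccoc3)cc2)o1` gives 21000 nM in this assay, the highest of the two numbers, with compound 2 within the scatter of it, so no order between the two is claimed. Compound 4 `Clc1cccc(Cl)c1Cc1nnc(Nc2ccc(COCc3cccnc3)cc2)o1` differs from compound 3 by pyridin-3-yl in place of furan-3-yl on a saturated chain carbon bound to an oxygen on a saturated carbon. Among the compounds with values here, no step between measured compounds is available to gauge this change, and the series gives no ground for a shift beyond the scatter in this assay. Compound 4 is therefore expected near 24000 nM, within 8000 nM to 75000 nM, an estimated step of a 1.1-fold higher number from compound 3 to compound 4 (0.06 log units; within the scatter).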

Compound 4, half-maximal cytotoxic concentration: 81000 nM
For compound 4 the middle estimate is 3.4-fold (0.53 log units) below the measured one, and the stated range ends below it.
By their numbers in this assay, from the lowest: compounds 2 and 3 (each within the scatter of the next); then compound 4. At a limit, above all of these: compound 1.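

In this assay the place on a saturated chain carbon bound to an oxygen on a saturated carbon proves sensitive to the aromatic ring it carries: pyridin-3-yl in place of furan-3-yl gives a 3.9-fold higher number from compound 3 to compound 4 (0.59 log units; beyond the scatter) and points to lower toxicity in this test. Within the data shown here, this is the only readable step, so the effect rests on one pair. Nothing measured here bears on the origin of this shift. Going by these compounds, whether an amine, a carboxylic acid or a longer chain at this place would move the number further stays open, as does whether the step carries over to the core of compound 1.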